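The source may report more compounds than this note shows. Statements on the series, on what has been measured and on what is new or still open speak of the compounds shown alone.

Compound 1 `CCC(C)(C)Cc1c[nH]c(CCc2ccc(-n3cccn3)cc2)n1`: 33 nM
Compound 2 `CCC(C)(C)Cc1c[nH]c(CCc2ccc(-c3cnsc3)cc2)n1`: 10 nM

In an in vitro assay on CHO cells for displacement of a labelled ligand from Bombesin receptor subtype-3 (Homo sapiens), read by scintillation counting, with a stated time of 2 h (on this read-out lower numbers stand for stronger inhibition and higher numbers for weaker inhibition), compound 1 stands highest of the two numbers; its nearest neighbour is compound 2, a 3.3-fold lower number from compound 1 to compound 2 (0.52 log units; beyond the scatter). Compound 3 `CCC(C)(C)Cc1c[nH]c(CCc2ccc(-c3cccnc3C(=O)O)cc2)n1` departs from compound 1 at the same aromatic carbon: 2-carboxypyridin-3-yl in place of 1H-pyrazol-1-yl on an aromatic carbon. For the measured compounds named here, the only measured step bearing on this position is the one from compound 1 to compound 2, a modest change on exchanging one five-membered ring for another. Here the entering group is a six-membered ring with a hydrogen-bond donor, a change no measured step covers, so only a small step is expected, a 1.2-fold higher number from compound 1 to compound 3 (0.08 log units; within the scatter). Compound 3 is estimated at 40 nM, within 10 nM to 160 nM.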

Compound 3, half-maximal inhibitory concentration: 560 nM
For compound 3 the middle estimate is 14-fold (1.15 log units) below the measured one; measured number above the stated range.
By their numbers in this assay, from the lowest: compound 2; then compound 1; then compound 3.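

This aromatic carbon, para to a large group, does not take every ring equally: 2-carboxypyridin-3-yl brings a 17-fold higher number from compound 1 to compound 3 (1.23 log units; beyond the scatter) and a 56-fold higher number from compound 2 to compound 3 (1.75 log units; beyond the scatter), both large steps, whereas the exchange of one five-membered ring for another had moved the number only modestly. The position therefore separates these groups far more sharply than compound 1 and compound 2 alone could show. Nothing available explains the rise. As far as these compounds go, it remains open whether the six-membered ring or the carboxylic acid carries the change; an unsubstituted pyridin-3-yl, or a methyl ester in place of the acid, would separate the two.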